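Aryl swaps on the vinyl chain: outlook for compound 4

A few compounds are considered here, and "the series" means these few. Any claim that something is new, unique, unknown or untested is made for them only; others in the source may bear on it.

Three analogues on one shared core have been run in a functional assay on HL-60 cells (Homo sapiens) for cytotoxicity, read by WST assay, with a stated time of 48 h; on this read-out higher numbers stand for weaker inhibition and lower numbers for stronger inhibition. Compound 1 `O[C@@H](c1ccccc1)[C@H]1CO[C@H](c2ccccc2)[C@@H](C/C=C/c2cccc(F)c2)C1` gives 9170 nM. Compound 2 `Oc1ccccc1/C=C/C[C@H]1C[C@@H]([C@@H](O)c2ccccc2)CO[C@@H]1c1ccccc1` gives 10800 nM, the second highest of the three numbers; the nearest number is that of compound 1 and the furthest that of compound 3 `Oc1cccc(/C=C/C[C@H]2C[C@@H]([C@@H](O)c3ccccc3)CO[C@@H]2c2ccccc2)c1`, which gives 12800 nM. The steps among them read a 1.2-fold higher number from compound 1 to compound 2 (0.07 log units; within the scatter), a 1.2-fold higher number from compound 2 to compound 3 (0.07 log units; within the scatter) and a 1.4-fold higher number from compound 1 to compound 3 (0.14 log units; within the scatter), all within the scatter.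

Compound 4 `O[C@@H](c1ccccc1)[C@H]1CO[C@H](c2ccccc2)[C@@H](C/C=C/c2cccnc2)C1` is not yet measured. It differs from compound 2 as follows: pyridin-3-yl in place of 2-hydroxyphenyl on a double-bonded chain carbon bound to a double-bonded chain carbon.

The measured steps that bear on this change are the two aryl swaps at the same chain position, a 1.2-fold higher number from compound 1 to compound 2 (0.07 log units; within the scatter) and a 1.2-fold higher number from compound 2 to compound 3 (0.07 log units; within the scatter), with a 1.4-fold higher number from compound 1 to compound 3 (0.14 log units; within the scatter) as the third. Among the compounds with values here, none of them reaches beyond the scatter, and no compound carrying pyridin-3-yl has been run. The expected step is therefore none beyond the scatter, a 1.0-fold lower number from compound 2 to compound 4 (0.01 log units; within the scatter). Compound 4 is estimated at 10500 nM, with a range of 4500 nM to 25000 nM.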

Compound 4, half-maximal inhibitory concentration: > 100000 nM
Compound 4: a limit, no number (the forecaster's own chance of this, stated with the estimate: 5%); middle value at least 9.5-fold (0.97 log units) from the limit.
By their numbers in this assay, from the lowest: compounds 1, 2 and 3 (each within the scatter of the next). At a limit, above all of these: compound 4.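

In this assay compound 4 stands at a limit of the assay, not at a number: the limit of > 100000 nM in this assay, at which 1 of the 4 values shown sits. Pyridin-3-yl on a double-bonded chain carbon bound to a double-bonded chain carbon gives an at least 9.2-fold higher number from compound 2 to compound 4 (0.96 log units; beyond the scatter), an at least 7.8-fold higher number from compound 3 to compound 4 (0.89 log units; beyond the scatter) and an at least 10-fold higher number from compound 1 to compound 4 (1.03 log units; beyond the scatter), and each of these steps is a bound set by that limit. The 3-fluorophenyl, 2-hydroxyphenyl and 3-hydroxyphenyl groups lie within the scatter of one another, so the flat picture they gave holds for these three groups only, and this position does respond to the choice of aromatic ring.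

The compounds shown do not separate the effect of the ring nitrogen from the loss of the hydroxy or fluoro substituent. A plain phenyl at this position would address that, and a pyridin-4-yl would test whether the outcome is specific to pyridin-3-yl.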